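Bis-aziridinyl quinones: moving the carbamate on a side chain

The source may hold more compounds than are shown below. What is called first, only, known or untested is meant among the compounds shown, and "the series" means these compounds.

Measured so far in a functional assay on L1210 cells (Mus musculus), with a stated time of 12 days; a lower number here means a less potent compound, a higher number a more potent compound, by a factor of ten per unit of this negative logarithm:
compound 1, `CC1=C(N2CC2)C(=O)C(CC(C)OC(N)=O)=C(N2CC2)C1=O`: 5.79
compound 2, `CN(C)C(=O)OCCC1=C(N2CC2)C(=O)C(CCOC(=O)N(C)C)=C(N2CC2)C1=O`: 4.85
compound 3, `CCCC1=C(N2CC2)C(=O)C(CCC)=C(N2CC2)C1=O`: 4.44

Compound 1 gives the highest number of the three in this assay; compound 2 sits lower by a margin beyond the scatter, and compound 3 lower still, also beyond the scatter. Only compound 1 carries a carbamate with a free amide hydrogen on a side chain, so nothing in the series isolates that feature on its own.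

Compound 4, `CC1=C(N2CC2)C(=O)C(CCCOC(N)=O)=C(N2CC2)C1=O`, is the next candidate for this assay. Against compound 1 the change is a group of 6 heavy atoms (3 carbon, 1 nitrogen, 2 oxygen; no ring) in place of a group of 6 heavy atoms (3 carbon, 1 nitrogen, 2 oxygen; no ring), on a saturated chain carbon bound to a double-bonded ring carbon. The same atoms are present in both; only the carbon the carbamate hangs from shifts along the chain. Among the measured compounds shown here, no measured pair shows a step of this kind, so its size is unknown. Given how small the rearrangement is, the step from compound 1 to compound 4 is expected to be a number 0.19 log units lower from compound 1 to compound 4 (within the scatter), within or just beyond the scatter, with no strong lean in either direction. Compound 4 is therefore estimated at 5.6, in the range 5 to 6.2.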

Compound 4, logarithm of the reciprocal of the active concentration, log(1/C): 5.93
Beside the measured number, compound 4's estimate is 0.33 log units below it; low and high end bracket the measured number.
By their numbers in this assay, from the lowest: compound 3; then compound 2; then compounds 1 and 4 (each within the scatter of the next).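

In this assay, among the compounds shown here, the change to 2-(carbamoyloxy)ethyl, with the same atoms joined differently, gives a number 0.14 log units higher from compound 1 to compound 4 (within the scatter) and so provides the first readable step. For the compounds shown here, on a saturated chain carbon bound to a double-bonded ring carbon, this shift of the carbamate along the side chain therefore leaves the number within the scatter, which the earlier compounds, none differing in only one place, could not show. No accompanying measurement bears on this result.

Compound 1 and compound 4 both keep the carbamate with its amide hydrogen, so the contribution of that group to the number remains unresolved. Also open, from the compounds shown here alone, is whether an amine, a carboxylic acid or a longer chain ending in the carbamate would keep the number at this position.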